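From 3-fluorophenyl to 4-fluorophenyl in the series

The source may hold more compounds than are shown below. What is called first, only, known or untested is meant among the compounds shown, and "the series" means these compounds.

In a functional assay on NCI-H460 cells (Homo sapiens) for antiproliferative activity, read by MTT assay, with a stated time of 48 h (a lower number here means a stronger inhibitor, a higher number a weaker inhibitor), compound 3 `COc1cc(-c2cccc3nc(-c4cccc(F)c4)oc23)cc(OC)c1OC` gives 3300 nM. Compound 1 `COc1ccc(-c2nc3cccc(-c4cc(OC)c(OC)c(OC)c4)c3o2)cc1` gives 3500 nM, which is within the scatter of the value for compound 3, so the two stand level. Compound 2 `COc1ccc(-c2nc3cccc(-c4cc(OC)c(OC)c(OC)c4)c3o2)cc1OC` reads > 25000 nM, which is a limit of the assay and not a number.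

The next structure is compound 4 `COc1cc(-c2cccc3nc(-c4ccc(F)cc4)oc23)cc(OC)c1OC`, still unmeasured. The change is 4-fluorophenyl in place of 3-fluorophenyl on an aromatic carbon, with 4-fluorophenyl in place of 3-fluorophenyl on an aromatic carbon.

For the measured compounds named here, no measured step makes this exact exchange, so the evidence is indirect. The closest step is 3-fluorophenyl in place of 4-methoxyphenyl, which gave a 1.1-fold lower number from compound 1 to compound 3 (0.03 log units; within the scatter). Two steps did go beyond the scatter: an at least 7.1-fold higher number from compound 1 to compound 2 (0.85 log units; beyond the scatter) and an at least 7.5-fold lower number from compound 2 to compound 3 (0.87 log units; beyond the scatter). Both involve the limit for compound 2 and an added or removed methoxy, which the present exchange does not touch. They therefore carry little weight here, although they show that this aryl group can matter in this assay.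

No step beyond the scatter is therefore expected, and the expected change is a 1.1-fold higher number from compound 3 to compound 4 (0.03 log units; within the scatter). For compound 4 the estimated value is 3500 nM, with an expected range of 1300 nM to 10000 nM.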

Compound 4, half-maximal inhibitory concentration: 8700 nM
For compound 4 the middle estimate is 2.5-fold (0.40 log units) below the measured one; the range from low to high includes it.
By their numbers in this assay, from the lowest: compounds 3 and 1 (each within the scatter of the next); then compound 4. At a limit, above all of these: compound 2.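

In this assay, for the compounds shown here, 4-fluorophenyl in place of 3-fluorophenyl gives a 2.6-fold higher number from compound 3 to compound 4 (0.42 log units; beyond the scatter), so this position separates two groups with the same atoms, joined differently, which no earlier step could show. Fluoro in place of methoxy gives a 2.5-fold higher number from compound 1 to compound 4 (0.40 log units; beyond the scatter), so 4-fluorophenyl does not stand level with 4-methoxyphenyl, although 3-fluorophenyl does, and the effect of a group here therefore cannot be read from the group alone. The third new reading, an at least 2.8-fold lower number from compound 2 to compound 4 (0.45 log units; beyond the scatter), rests on a limit of the assay and not a number, so it gives a bound only: the limit of > 25000 nM in this assay, at which 1 of the 4 values shown sits.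

Open is how 2-fluorophenyl, or a phenyl ring carrying an amine or a carboxylic acid, would read at this position, since the aryl groups shown carry only fluoro or methoxy. The remainder of the structure is the same in all four compounds, so the order of these aryl groups is known only for this one setting, and whether it would hold with a different group elsewhere on the core stays unanswered.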